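From 4-Nitrophenyl to 3-Chlorophenyl on a Shared Core

A few compounds are considered here, and "the series" means these few. Any claim that something is new, unique, unknown or untested is made for them only; others in the source may bear on it.

In a functional assay on HT-29 cells (Homo sapiens) for cytotoxicity, read by sulforhodamine B assay (a higher number here means a weaker inhibitor of growth, a lower number a stronger inhibitor of growth), compound 3 `CC1=CC[C@@H]([C@@](C)(O)CCCC(C)(C)NC(=S)N/N=C\c2ccc([N+](=O)[O-])cc2)CC1` gives 62800 nM and compound 1 `CC1=CC[C@@H]([C@@](C)(O)CCCC(C)(C)NC(=S)N/N=C\c2ccc(O)cc2)CC1` gives 31500 nM. These two values lie close together, with a 2.0-fold higher number from compound 1 to compound 3 (0.30 log units; within the scatter). Compound 2 `CC1=CC[C@@H]([C@@](C)(O)CCCC(C)(C)NC(=S)N/N=C\c2ccc(N(C)C)cc2)CC1` reads > 100000 nM, which is a limit of the assay and not a number. Going by the values given here, only one measured change on the aromatic group clears the scatter, with an at least 3.1-fold higher number from compound 1 to compound 2 (0.50 log units; beyond the scatter). Compound 4 `CC1=CC[C@@H]([C@@](C)(O)CCCC(C)(C)NC(=S)N/N=C\c2cccc(Cl)c2)CC1` differs from compound 3 by 3-chlorophenyl in place of 4-nitrophenyl on a carbon with a double bond to nitrogen, placing 3-chlorophenyl in place of 4-nitrophenyl on a carbon with a double bond to nitrogen. Among the compounds with values here, no measured step makes this exact swap, and the closest one, a 2.0-fold higher number from compound 1 to compound 3 (0.30 log units; within the scatter), is small, so no change beyond the scatter is expected. The expected step is a 1.3-fold lower number from compound 3 to compound 4 (0.12 log units; within the scatter). Compound 4 is estimated at 48000 nM, within a range from 20000 nM to 100000 nM.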

Compound 4, concentration for total growth inhibition: 16500 nM
The estimate for compound 4 lay 2.9-fold (0.46 log units) above the measured number, outside the stated range (below it).
By their numbers in this assay, from the lowest: compounds 4, 1 and 3 (each within the scatter of the next, the first and the last beyond it). At a limit, above all of these: compound 2.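

Going by these compounds alone, for the first time, a change at this carbon lowers the number beyond the scatter, with a 3.8-fold lower number from compound 3 to compound 4 (0.58 log units; beyond the scatter). Yet 3-chlorophenyl does not separate from 4-hydroxyphenyl, with a 1.9-fold lower number from compound 1 to compound 4 (0.28 log units; within the scatter). The comparison with 4-(dimethylamino)phenyl gives only a floor, an at least 6.0-fold lower number from compound 2 to compound 4 (0.78 log units; beyond the scatter), as the value of compound 2 is a limit and not a number: the limit of > 100000 nM in this assay, at which 1 of the 4 values shown sits.

Still open, as far as these compounds go, is whether the chlorine itself or its position on the ring matters. 4-Chlorophenyl or 3-nitrophenyl on this carbon would separate the two.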